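The source may report more compounds than this note shows. Statements on the series, on what has been measured and on what is new or still open speak of the compounds shown alone.

Compound 1 `CC(=O)c1ccc2c(c1)N(C1=CCCC1=O)CC(C)(C)S2`: 1.45 nM
Compound 2 `CC1(C)CN(C2=CCCC2=O)c2cc(C(F)(F)F)ccc2S1`: 0.0417 nM

For the measured compounds named here, in a functional assay on aorta (Rattus norvegicus, strain Wistar) (on this read-out lower numbers stand for stronger inhibition and higher numbers for weaker inhibition), compound 1 gives the higher of the two numbers measured so far, so of these two it is the weaker inhibitor; its only neighbour is compound 2, reached by a 35-fold lower number from compound 1 to compound 2 (1.54 log units; beyond the scatter). Compound 3 `CC1(C)CN(C2=CCCC2=O)c2ccccc2S1` has not yet been measured. It differs from compound 1 in a single place: hydrogen in place of acetyl on an aromatic carbon. Going by the values given here, the one measured step bears on this only loosely. It shows that exchanging the group at this aromatic carbon can shift the number a great deal, but that step swaps acetyl for trifluoromethyl, not for hydrogen, and therefore gives no direction for the present change. With no closer comparison available, the expected step of a 1.7-fold higher number from compound 1 to compound 3 (0.24 log units; within the scatter) is small, carrying wide uncertainty in both directions. Compound 3 is accordingly estimated at 2.5 nM, within a range from 0.4 nM to 15 nM.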

Compound 3, half-maximal inhibitory concentration: 724 nM
Compound 3: middle estimate off by 290-fold (2.46 log units), on the low side; measured number outside the range, above it.
By their numbers in this assay, from the lowest: compound 2; then compound 1; then compound 3.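

In this assay, replacing acetyl with hydrogen on this aromatic carbon (a 500-fold higher number from compound 1 to compound 3 (2.70 log units; beyond the scatter)) changes the number even more than exchanging acetyl for trifluoromethyl did, and replacing trifluoromethyl with hydrogen gives the largest step (a 17000-fold higher number from compound 2 to compound 3 (4.24 log units; beyond the scatter)). For the compounds shown here, the earlier pair could compare only one group with another, whereas compound 3 provides the unsubstituted reference. Against that reference, both acetyl and trifluoromethyl go with much stronger inhibition than hydrogen, so the group at this carbon has a very large influence on the result in this series.

A nitrile or a single chlorine atom at this carbon would test whether other groups also give such low numbers, or whether this is limited to the two groups shown. Nothing measured here explains the size of these steps.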